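Series notes: nitro in place of methoxy on the aryl ring

A few compounds are considered here, and "the series" means these few. Any claim that something is new, unique, unknown or untested is made for them only; others in the source may bear on it.

Measured so far:
compound 1 `COc1cccc(/C=C/C(=O)c2ccc(OC)c3c2OC(C)(C)C=C3)c1` — > 10000 nM
compound 2 `COc1ccc(C(=O)/C=C/c2ccc(-c3ccccc3)cc2)c2c1C=CC(C)(C)O2` — > 10000 nM

Both entries stand at a limit of the assay rather than at a number. In a functional assay on K562 cells (Homo sapiens) for antiproliferative activity, read by MTT assay, with a stated time of 24 h (a lower number here means a stronger inhibitor, a higher number a weaker inhibitor), compound 1 gives > 10000 nM, which is a limit. Compound 2 gives > 10000 nM in this assay, again a limit. Compound 1 therefore has no measured position on a scale; what is known is only (the limit of > 10000 nM in this assay, at which 2 of the 2 values shown sit). Going by the values given here, no step between measured compounds can be computed, since no pair differs in one place.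

Compound 3 `COc1ccc(C(=O)/C=C/c2cccc([N+](=O)[O-])c2)c2c1C=CC(C)(C)O2` is not yet measured in this assay. It differs from compound 1 by nitro in place of methoxy on an aromatic carbon; in words, nitro in place of methoxy on an aromatic carbon. No measured step carries information on this change, so no direction beyond the scatter can be read from the shown data. The expected step that the limit leaves unreadable from compound 1 to compound 3 is taken as near zero because compound 1 stands at the limit of > 10000 nM in this assay, at which 2 of the 2 values shown sit. For compound 3 the estimate in this assay is 15000 nM, with a range from 3000 nM to 60000 nM, and the most likely outcome is once more a limit.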

Compound 3, half-maximal inhibitory concentration: 5870 nM
For compound 3 the middle estimate is 2.6-fold (0.41 log units) above the measured one; the measured number falls inside the stated range.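

In this assay, going by these compounds alone, compound 3 gives 5870 nM, the only value in this set that is a number rather than a limit, so this position on the aryl ring can carry a readable result in this assay. Compound 1 gives > 10000 nM, which is a limit. From the compounds shown here alone, the change from 3-methoxyphenyl to 3-nitrophenyl gives an at least 1.7-fold lower number from compound 1 to compound 3 (0.23 log units; that floor lies within the scatter), so the data support no firm claim of a gain, and the true size of the step stays unknown because the starting point is only a limit: the limit of > 10000 nM in this assay, at which 2 of the 3 values shown sit.

The compounds shown leave open whether an amine, a carboxylic acid or a nitrile on the same aromatic carbon would read like the nitro group of compound 3, or whether this group stands apart from such replacements. Within the data shown here, also open is whether nitro in place of methoxy gives the same direction on a different core, since this single pair, with its limit at one end, is the only evidence on the change so far.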